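The source may report more compounds than this note shows. Statements on the series, on what has been measured and on what is new or still open speak of the compounds shown alone.

Compound 1 `CC(C)c1ccc(OC(C)(Cc2ccc(Cl)cc2)C(=O)NS(C)(=O)=O)cc1`: 5 mg/kg
Compound 2 `COc1ccc(S(=O)(=O)NC(=O)C(C)(Cc2ccc(Cl)cc2)Oc2ccc(C(C)C)cc2)cc1`: > 10 mg/kg

Among the measured compounds shown here, in a functional assay on the whole organism for inhibition, with Rattus norvegicus as the target (a higher number here means that more compound is needed for the effect, a lower number that less compound is needed), compound 1 gives 5 mg/kg, the only exact number so far. Compound 2 reads > 10 mg/kg, which is a limit of the assay and not a number. For the measured compounds named here, the single measured step, with 4-methoxyphenyl in place of methyl on a sulfonyl sulfur, is an at least 2.0-fold higher number from compound 1 to compound 2 (0.30 log units; that floor lies within the scatter).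

Compound 3 `CC(C)c1ccc(OC(C)(CO)Cc2ccc(Cl)cc2)cc1` changes the same part of compound 1 far more deeply: hydroxymethyl in place of (methylsulfonyl)carbamoyl on a saturated chain carbon bound to an oxygen on an aromatic ring and two saturated chain carbons. Going by the values given here, the whole (methylsulfonyl)carbamoyl goes, whereas compound 2 keeps it and alters only its methyl, and no measured step covers such a swap. The step to compound 2, an at least 2.0-fold higher number from compound 1 to compound 2 (0.30 log units; that floor lies within the scatter), offers only a weak hint, pointing towards a higher number in this assay. A modest rise is expected, and a reading that is only a limit would be no surprise. The expected change is a 3.0-fold higher number from compound 1 to compound 3 (0.48 log units; beyond the scatter). For compound 3 the estimate is 15 mg/kg, with an expected range from 5 mg/kg to 50 mg/kg.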

Compound 3, dose for half-maximal effect: 10 mg/kg
Estimate against measurement, compound 3: 1.5-fold (0.18 log units) above; low and high end bracket the measured number.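

Up to this point, only the methyl of the (methylsulfonyl)carbamoyl had been altered, and that step ended in a limit rather than an exact number. Compound 3 removes the whole group and puts a much smaller hydroxymethyl on the same saturated chain carbon, and this assay shows a 2.0-fold higher number from compound 1 to compound 3 (0.30 log units; within the scatter). For this pair, then, the effect in the rat does not depend on keeping the (methylsulfonyl)carbamoyl, since a far simpler group gives a reading that cannot be told apart from that of compound 1.

Compound 2 remains a limit and not a number: the limit of > 10 mg/kg in this assay, at which 1 of the 3 values shown sits. The compounds shown also leave open how this position responds to other replacements on the same carbon, such as a carboxylic acid or an amine, and whether either would give a reading clearly beyond the scatter.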